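Fluoro for hydroxy at the hydrazone aryl end

This account rests on a few compounds, and the source may have more. Where it says the series, first, only, none or still open, it means among the compounds named here.

Of the compounds shown here, two sharing a common core have so far been measured in a physicochemical assay for lipophilicity, measured as octanol-water partition; on this read-out lower numbers stand for lower lipophilicity and higher numbers for higher lipophilicity. Compound 1, `O=C(COc1cccc2ccccc12)N/N=C/c1ccc(O)cc1`, gives 3.73 in this assay, the higher of the two numbers recorded. Compound 2, `C/C(=N\NC(=O)COc1cccc2ccccc12)c1ccc([N+](=O)[O-])cc1`, gives 3.37 in this assay, a number that lies beyond the usual scatter below that of compound 1. Within the data shown here, no single-point step between these two measured compounds is recorded, so only their two values can be compared.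

Compound 3, `O=C(COc1cccc2ccccc12)N/N=C/c1ccc(F)cc1`, is the next candidate for this assay. It differs from compound 1 in one place: fluoro in place of hydroxy on an aromatic carbon. The group that leaves sits on an aromatic carbon of a six-membered aromatic ring of carbon only, para to a large group, and the group that enters takes the same position.

Compound 3 is expected to move upward, with a step of a number 0.67 log units higher from compound 1 to compound 3 (beyond the scatter) in this assay, a step clearly beyond the scatter. Starting from compound 1 at 3.73, compound 3 is accordingly estimated at 4.4 in this assay, within a range from 4 to 4.9.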

Compound 3, partition coefficient: 4.16
Compound 3: middle estimate off by 0.24 log units, on the high side; the measured number falls inside the stated range.
By their numbers in this assay, from the lowest: compound 2; then compound 1; then compound 3.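

In this assay, among these compounds, the swap gives the first single-change comparison: a number 0.43 log units higher from compound 1 to compound 3 (beyond the scatter). With only compound 1 and compound 2 measured before, no effect could be assigned to one place, whereas this pair shows that the read-out responds to the group on an aromatic carbon para to a large group, with the rest of the structure held constant. The change from 4-hydroxyphenyl to 4-fluorophenyl takes away the hydrogen-bond donor and acceptor counted for hydroxy, but this single pair cannot separate that difference from any other difference between the two groups, and no supporting measurement bears on the reason for the step.

The compounds shown leave open how the read-out would respond to a chloro, a methoxy, an amine or a carboxylic acid at this same position. They also leave open whether fluoro in place of hydroxy would produce a step of similar size on a different core, since this change is represented by one pair alone.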